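Cytotoxicity of a Bromophenyl Triazole Butenolide Analogue

The source may hold more compounds than are shown below. What is called first, only, known or untested is meant among the compounds shown, and "the series" means these compounds.

Compound 1 `COc1ccc(-c2cn(C/C=C3\OC(=O)C(OCc4ccccc4)=C3OCc3ccccc3)nn2)cc1`: in an ADME assay on HFF cells (Homo sapiens) for cytotoxicity, read by MTT assay, with a stated time of 72 h (a lower number here means a stronger inhibitor, a higher number a weaker inhibitor), compound 1 gives > 100000 nM, which is a limit of the assay and not a number.
Compound 2 `O=C1O/C(=C\Cn2cc(-c3cc(F)cc(F)c3)nn2)C(OCc2ccccc2)=C1OCc1ccccc1`: in this assay compound 2 gives > 100000 nM, again a limit rather than a number.
Compound 3 `COc1ccc(-c2cn(C[C@H](O)[C@H]3OC(=O)C(OCc4ccccc4)=C3OCc3ccccc3)nn2)cc1`: in this assay compound 3 gives < 10 nM, also a limit.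

Compound 2 therefore stands at the weak end of what the numbers show; it shares the limit of > 100000 nM in this assay, at which 2 of the 3 values shown sit, with compound 1, while compound 3 sits at the limit of < 10 nM in this assay, at which 1 of the 3 values shown sits. Among the measured compounds shown here, the only measured step that touches compound 2 is a step that the two limits leave unreadable from compound 1 to compound 2, whose size cannot be read from two limits.

The step to compound 4 `O=C1O/C(=C\Cn2cc(-c3ccc(Br)cc3)nn2)C(OCc2ccccc2)=C1OCc1ccccc1` is 4-bromophenyl in place of 3,5-difluorophenyl on an aromatic carbon. This exchanges one aryl group for another on the same shared core that compound 2 and compound 1 carry, and both of those compounds sit at the same upper limit. For the measured compounds named here, no measured step speaks for a change in the growth-inhibiting strength, so the step of a number no higher from compound 2 to compound 4 (the limit leaves the size open) is expected to be none beyond the scatter. Compound 4 is thus estimated to give 100000 nM in this assay, with a range from 30000 nM to 300000 nM, most likely reported only as a limit.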

Compound 4, half-maximal inhibitory concentration: > 100000 nM
Compound 4 gave a limit, no number; the forecaster's own chance of this, stated with the estimate: 80%; the middle value sits exactly at the limit.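

In this assay compound 4 gives > 100000 nM, a limit and not a number. Its steps from compound 1 and from compound 2 join limits only, and their size cannot be read. Left open is whether compound 1, compound 2 and compound 4 differ at all in this assay.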